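Aryloxy pyrazole imine coumarins: antiproliferative working notes

A few compounds are considered here, and "the series" means these few. Any claim that something is new, unique, unknown or untested is made for them only; others in the source may bear on it.

Measured so far:
compound 1, `Cc1nn(C)c(Oc2cccc(F)c2)c1/C=N\CCCCCOc1cc2oc(=O)cc(C)c2cc1Cl`, 9870 nM
compound 2, `Cc1nn(C)c(Oc2ccccc2F)c1/C=N\CCCCCCOc1cc2oc(=O)cc(C)c2cc1Cl`, > 25000 nM

In a functional assay on U-87MG ATCC cells for antiproliferative activity against U-87 MG (Homo sapiens), read by MTT assay, with a stated time of 72 h (on this read-out lower numbers stand for stronger inhibition and higher numbers for weaker inhibition), compound 1 gives 9870 nM. In this assay compound 2 is reported only as a limit, > 25000 nM, and so compound 2 stands at the limit of > 25000 nM in this assay, at which 1 of the 2 values shown sits. Compound 3, `Cc1nn(C)c(Oc2ccc(Cl)cc2)c1/C=N\CCCCCCOc1cc2oc(=O)cc(C)c2cc1Cl`, is not yet measured; it differs from compound 2 by 4-chlorophenyl in place of 2-fluorophenyl on an oxygen on an aromatic ring. Within the data shown here, no measured step covers this change, so the expected shift is small and without a clear direction beyond the scatter; the estimated step is an at least 1.1-fold lower number from compound 2 to compound 3 (0.05 log units; that floor lies within the scatter). Compound 3 is expected near 22000 nM, within 7000 nM to 70000 nM.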

Compound 3, half-maximal inhibitory concentration: 3850 nM
Estimate against measurement, compound 3: 5.7-fold (0.76 log units) above, outside the stated range (below it).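

With the rest of the structure unchanged, the aryl group on the oxygen is shown to matter in this assay: 4-chlorophenyl in place of 2-fluorophenyl gives an at least 6.4-fold lower number from compound 2 to compound 3 (0.81 log units; beyond the scatter). Among these compounds, that step is the first readable one, and it is a floor. Compound 2 is reported only as a limit: the limit of > 25000 nM in this assay, at which 1 of the 3 values shown sits.

The change swaps both the halogen and its place on the ring, and the compounds shown cannot separate the two. A 4-fluorophenyl or 2-chlorophenyl group on the same oxygen would divide them.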